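Hydroxamate chain shortening on two cores

This account rests on a few compounds, and the source may have more. Where it says the series, first, only, none or still open, it means among the compounds named here.

Compound 1 `O=C(/C=C/c1ccc(OCc2nc(C3CCN(Cc4ccccc4)CC3)no2)cc1)NO` and compound 2 `O=C(NO)c1ccc(OCc2nc(C3CCN(Cc4ccccc4)CC3)no2)cc1` share one core; compound 3 `CN(Cc1nc(C2CCN(Cc3ccccc3)CC2)no1)c1ncc(/C=C/C(=O)NO)cn1` and compound 4 `CN(Cc1nc(C2CCN(Cc3ccccc3)CC2)no1)c1ncc(C(=O)NO)cn1` share another. The difference between the two cores is not broken down here. In an assay on isolated protein for inhibition of protein deacetylase HDAC6 (Homo sapiens), read by fluorescence, with a stated time of 1 h, tested at 100 nM (a lower number here means less inhibition, a higher number more inhibition at the concentration tested (going by the name of the read-out)), compound 1 gives 71% and compound 2 gives 66%; the step of a number 5 percentage points lower from compound 1 to compound 2 (within the scatter) belongs to the change (hydroxycarbamoyl in place of 2-(hydroxycarbamoyl)ethenyl on an aromatic carbon). In this assay compound 3 gives 55%, the lowest of the three and beyond the scatter from both compound 1 and compound 2. Compound 4 carries the same kind of change, (hydroxycarbamoyl in place of 2-(hydroxycarbamoyl)ethenyl on an aromatic carbon), here on a ring with two nitrogen and two atoms from the ring nitrogen rather than on a ring of carbon only. Because a number 5 percentage points lower from compound 1 to compound 2 (within the scatter) stayed within the scatter, the expected step is a number 5 percentage points lower from compound 3 to compound 4 (within the scatter). The estimate for compound 4 in this assay is 50%, with a range from 35% to 65%.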

Compound 4, a percentage reported as inhibition, at one concentration (the size of the read-out at that concentration, not a potency): 63%
The estimate for compound 4 lay 13 percentage points below the measured number; low and high end bracket the measured number.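

In this assay, hydroxycarbamoyl in place of 2-(hydroxycarbamoyl)ethenyl gives a number 8 percentage points higher from compound 3 to compound 4 (within the scatter) on this core, so the number is level here as it is on the core of compound 1. The two steps do not differ beyond what repeated measurement allows: the same change on two cores in this assay, a number 5 percentage points lower (within the scatter) from compound 1 to compound 2 and a number 8 percentage points higher (within the scatter) from compound 3 to compound 4, 13 percentage points apart, within the scatter of two such steps. Within each pair the two compounds cannot be told apart at the single concentration tested, but two pairs fix no direction for the change and give no potency.

Open, going by these compounds, is how a longer chain ending in hydroxycarbamoyl, or a carboxylic acid in its place, would read on these two cores. Also open, on these data alone, is whether the change carries over to any further core.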